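The source may hold more compounds than are shown below. What is called first, only, known or untested is meant among the compounds shown, and "the series" means these compounds.

Measured so far:
Compound 1, `Cc1ccc2oc(=O)n(CCN3CCN(c4ccccc4)CC3)c2n1` — in a functional assay on the whole organism with Mus musculus as the target (a lower number here means that less compound is needed, a higher number that more compound is needed for the effect), compound 1 gives > 50 mg/kg.
Compound 2, `CN1CCN(CCn2c(=O)oc3cccnc32)CC1` — in this assay compound 2 gives > 25 mg/kg.

Both numbers are limits of the assay rather than measured doses. For compound 2 the figure stands at the limit of > 25 mg/kg in this assay, at which 1 of the 2 values shown sits, so the dose for half-maximal effect was not reached, and compound 2 is only placed beyond that point. For compound 1 the figure stands at the limit of > 50 mg/kg in this assay, at which 1 of the 2 values shown sits, again a limit and not a number. No step between the two measured compounds is shown, and their values say only that neither reached a half-maximal effect within the doses tested.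

Compound 3, `O=c1oc2cccnc2n1CCN1CCN(c2ccccc2)CC1`, is not yet measured in this assay. It differs from compound 2 by phenyl in place of methyl on an amine nitrogen in a ring. Since compound 1 carries that same phenyl on the ring nitrogen and reaches only a limit, compound 3 is expected to behave much the same, and the step that the limit leaves unreadable from compound 2 to compound 3 is estimated to be none beyond the scatter. For compound 3 the expected value is 60 mg/kg, within a range from 25 mg/kg to 150 mg/kg.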

Compound 3, dose for half-maximal effect: 19.4 mg/kg
For compound 3 the middle estimate is 3.1-fold (0.49 log units) above the measured one, outside the stated range (below it).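

In this assay, as far as these compounds go, phenyl in place of methyl on an amine nitrogen in a ring gives an at least 1.2-fold lower number from compound 2 to compound 3 (0.11 log units; that floor lies within the scatter), so the change at this position comes with the first dose that is an actual number, yet the step can be read only as a floor and the true size of the change remains unknown. The figure for compound 2 is a limit and not a number: the limit of > 25 mg/kg in this assay, at which 1 of the 3 values shown sits. The second step shows that phenyl at this position does not settle the outcome alone, since with that phenyl held constant, hydrogen in place of methyl on an aromatic carbon gives an at least 2.5-fold lower number from compound 1 to compound 3 (0.41 log units; beyond the scatter), a floor that is already clear of the usual scatter.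

From the compounds shown here alone, how far compound 2 truly lies from compound 3 stays open, as does the real distance from compound 1 to compound 3. Also open, going by these compounds, is whether a benzyl group on the same amine nitrogen, or a chlorine atom in place of that aromatic methyl, would give a measurable dose in this whole-animal setting.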